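The source may report more compounds than this note shows. Statements on the series, on what has been measured and on what is new or still open speak of the compounds shown alone.

Measured so far:
compound 1 `COC1=CC(=O)c2c(c(COCc3ccccc3)c(C)n2C)C1=O` gives 410000 nM
compound 2 `COC1=CC(=O)c2c(c(COc3ccc(F)cc3)c(C)n2C)C1=O` gives 850 nM

In a functional assay on V79-379A cells (Cricetulus griseus) for cytotoxicity, read by MTT assay, in the presence of a further agent that is not named here (on this read-out higher numbers stand for weaker inhibition and lower numbers for stronger inhibition), compound 2 holds the lower of the two numbers. Among the measured compounds shown here, compound 3 `COC1=CC(=O)c2c(c(Cc3ccc(O)c(F)c3)c(C)n2C)C1=O` has the same atoms joined differently, with 3-fluoro-4-hydroxyphenyl in place of 4-fluorophenoxy on a saturated chain carbon bound to an aromatic carbon as the single change. For the measured compounds named here, only one measured step bears on this, a 480-fold lower number from compound 1 to compound 2 (2.68 log units; beyond the scatter), and it is large. Neither measured compound carries 3-fluoro-4-hydroxyphenyl, so the size stays uncertain. With compound 2 at the low end of the numbers seen, a large move towards a higher number is expected, a 47-fold higher number from compound 2 to compound 3 (1.67 log units; beyond the scatter) as estimated. The estimate for compound 3 is 40000 nM within an expected range from 3000 nM to 400000 nM overall.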

Compound 3, half-maximal inhibitory concentration: 280000 nM
Estimate against measurement, compound 3: 7.0-fold (0.85 log units) below; the range from low to high includes it.
By their numbers in this assay, from the lowest: compound 2; then compounds 3 and 1 (each within the scatter of the next).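

In this assay the same atoms joined differently give a 330-fold higher number from compound 2 to compound 3 (2.52 log units; beyond the scatter) on a saturated chain carbon bound to an aromatic carbon, so the arrangement of the group alone separates these two compounds. Replacing benzyloxy with 3-fluoro-4-hydroxyphenyl gives a 1.5-fold lower number from compound 1 to compound 3 (0.17 log units; within the scatter) and leaves the read-out unresolved between them, so among the three groups only 4-fluorophenoxy stands apart. No evidence available here accounts for the difference. Open, from the compounds shown here alone, is whether unsubstituted phenoxy, or an amine linking the 4-fluorophenyl ring in place of the oxygen, keeps the low number of compound 2.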